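The compounds below may be only part of what the source reports. "The series", "measured", "known", "first", "only" and "open" are said of these compounds alone.

Measured so far:
Compound 1, `Cc1n[nH]c(C(=O)O)c1Cc1cccc(-c2ccc(C#N)cc2)c1`, gives 46% in an assay on isolated protein for inhibition of 2-Hydroxyacid oxidase 2 (Homo sapiens), tested at 10 uM; on this read-out higher numbers stand for a stronger effect at the one concentration tested and lower numbers for a weaker effect.
Compound 2, `Cc1n[nH]c(C(=O)O)c1Cc1cccc(-c2ccc(C(N)=O)cc2)c1`, gives 60% in this assay.

Compound 2 stands highest of the two numbers; its nearest neighbour is compound 1, which lies lower by a step beyond the scatter. The two share one core and differ only in the group on an aromatic carbon of the six-membered aromatic ring of carbon only. Compound 3, `Cc1n[nH]c(C(=O)O)c1Cc1cccc(-c2ccc(C(F)(F)F)cc2)c1`, keeps that core but carries another group at that place: trifluoromethyl in place of carbamoyl on an aromatic carbon. For the measured compounds named here, only one measured step bears on this position. That step, a number 14 percentage points higher from compound 1 to compound 2 (beyond the scatter), shows that carbamoyl gives a modestly higher number than cyano there. Nothing measured shows how trifluoromethyl fares at this place, so the expectation rests on compound 2 alone and is uncertain. Compound 3 is expected to give up the gain seen with carbamoyl, an estimated step of a number 15 percentage points lower from compound 2 to compound 3 (beyond the scatter). Compound 3 is estimated at 45%, within a range from 25% to 65%.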

Compound 3, a percentage reported as inhibition, at one concentration (the size of the read-out at that concentration, not a potency): 30%
The estimate for compound 3 lay 15 percentage points above the measured number; the measured number falls inside the stated range.
By their numbers in this assay, from the lowest: compound 3; then compound 1; then compound 2.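

Adding a third group shows that the choice at this place can move the number in either direction. Trifluoromethyl in place of carbamoyl gives a number 30 percentage points lower from compound 2 to compound 3 (beyond the scatter), and trifluoromethyl in place of cyano gives a number 16 percentage points lower from compound 1 to compound 3 (beyond the scatter), so cyano now sits between the other two groups in this assay. Carbamoyl carries a hydrogen-bond donor and acceptor where trifluoromethyl carries neither, but nothing available explains why these three groups fall in this order.

For the compounds shown here, with only three groups compared, it remains open whether the higher number is specific to carbamoyl or also extends to related groups. A carboxylic acid, an amine or an N-methyl amide at this place would help to separate those possibilities.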